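The source may report more compounds than this note shows. Statements on the series, on what has been measured and on what is new or still open speak of the compounds shown alone.

Among the measured compounds shown here, in an ADME assay on CHO cells (Cricetulus griseus) for inhibition, read by MTT assay (a lower number here means a stronger inhibitor, a higher number a weaker inhibitor), the compounds measured so far all sit at high numbers, meaning weak inhibition. Compound 2 `CC(C)(C)NCc1cc(C(C)(C)C)cc(Nc2nc3cc(F)c(F)cc3[nH]2)c1O` gives 34200 nM, and compound 3 `Cc1cc(CNC(C)(C)C)c(O)c(Nc2nc3cc(F)c(F)cc3[nH]2)c1` gives 16700 nM, the lower of the two actual numbers. Swapping tert-butyl for methyl accounts for a 2.0-fold lower number from compound 2 to compound 3 (0.31 log units; beyond the scatter). Compound 1 `CC(C)(C)NCc1cc(Cl)cc(Nc2nc3cc(F)c(F)cc3n2Cc2ccc(C(F)(F)F)cc2)c1O` reads > 50000 nM, which is a limit of the assay and not a number.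

The next structure, compound 4 `Cc1cc(CNC(C)(C)C)c(O)c(Nc2nc3cc(F)c(F)cc3n2Cc2ccc(C(F)(F)F)cc2)c1`, keeps compound 3 intact except on an aromatic nitrogen, where 4-(trifluoromethyl)benzyl replaces hydrogen: 4-(trifluoromethyl)benzyl in place of hydrogen on an aromatic nitrogen. For the measured compounds named here, no measured step isolates this change. The step of a 2.0-fold lower number from compound 2 to compound 3 (0.31 log units; beyond the scatter) is modest and lies at another place, so it says little about the new group. Going by the values given here, compound 1 is the only measured compound that already carries 4-(trifluoromethyl)benzyl, and its reading of > 50000 nM is the best guide, although it differs from compound 3 in more than one place. That points towards a higher number in this assay, and a reading that is only a limit is quite possible. The expected change is a 1.8-fold higher number from compound 3 to compound 4 (0.25 log units; within the scatter). Compound 4 is estimated at 30000 nM, with an expected range from 10000 nM to 50000 nM.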

Compound 4, half-maximal inhibitory concentration: 10000 nM
Compound 4: middle estimate off by 3.0-fold (0.48 log units), on the high side, within the range that was stated.
By their numbers in this assay, from the lowest: compounds 4 and 3 (each within the scatter of the next); then compound 2. At a limit, above all of these: compound 1.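

Among the compounds shown here, putting 4-(trifluoromethyl)benzyl in place of hydrogen on the aromatic nitrogen gives a 1.7-fold lower number from compound 3 to compound 4 (0.22 log units; within the scatter), so this large group, tested on its own for the first time, does not separate the two compounds in this assay. Compound 1 carries the same group and reads > 50000 nM, which is a limit of the assay and not a number. Its very high reading therefore cannot be pinned on the benzyl group alone, and the change on the aromatic carbon, methyl in place of chloro, gives an at least 5.0-fold lower number from compound 1 to compound 4 (0.69 log units; beyond the scatter), a step that rests on a limit: the limit of > 50000 nM in this assay, at which 1 of the 4 values shown sits.

The compounds shown leave open whether the quiet result at this nitrogen holds for other groups there, such as a plain methyl, a longer chain or a chain ending in an amine, or for a carboxylic acid in place of the trifluoromethyl on the benzyl ring. From the compounds shown here alone, it also remains open how chloro on that aromatic carbon reads when the nitrogen keeps its hydrogen, a comparison that would show whether the chloro effect depends on the benzyl group.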